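The source may hold more compounds than are shown below. What is called first, only, known or untested is meant among the compounds shown, and "the series" means these compounds.

Compound 1 `Fc1ccc(C2CC(c3ccc(Cl)s3)=NN2c2nc(-c3ccccc3)cs2)cc1` gives > 500 ug/mL in an ADME assay on NIH3T3 cells (Mus musculus) for cytotoxicity, read by XTT assay, with a stated time of 24 h (a higher number here means a weaker inhibitor, a lower number a stronger inhibitor), which is a limit of the assay. Compound 2 `Cc1ccc(C2=NN(c3nc(-c4ccc(F)cc4)cs3)C(c3ccc(F)cc3)C2)s1` gives > 500 ug/mL, also a limit. Compound 3 `Cc1ccc(-c2csc(N3N=C(c4ccc(Cl)s4)CC3c3ccc(F)cc3)n2)cc1` gives > 500 ug/mL, again a limit.

Compound 2 therefore stands where every compound measured here stands, at the limit of > 500 ug/mL in this assay, at which 3 of the 3 values shown sit. For the measured compounds named here, the one step between measured compounds, a step that the two limits leave unreadable from compound 1 to compound 3, has a limit at both ends, and its size is not readable. Compound 4 `Cc1ccc(C2=NN(c3nc(-c4ccc(C(F)(F)F)cc4)cs3)C(c3ccc(F)cc3)C2)s1` differs from compound 2 by trifluoromethyl in place of fluoro on an aromatic carbon. Going by the values given here, no measured step bears on this change, so the only guide is that all three compounds sit at the limit. Compound 4 is expected to sit at the limit too, a step of a number no higher from compound 2 to compound 4 (the limit leaves the size open) expected to be none beyond the scatter. The estimate for compound 4 is 500 ug/mL, between 200 ug/mL and 1000 ug/mL.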

Compound 4, half-maximal inhibitory concentration: > 500 ug/mL
Compound 4 was reported as a limit; the forecaster's own chance of this, stated with the estimate: 85%; the middle value sits exactly at the limit.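

Compound 2 and compound 4 both sit at a limit of the assay, so the size of the step between them cannot be read: the limit of > 500 ug/mL in this assay, at which 4 of the 4 values shown sit. The compounds shown leave open what actual inhibitory concentration any of them has, and whether trifluoromethyl in place of fluoro changes it.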